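Adding one methoxy to compound 2

The source may hold more compounds than are shown below. What is called first, only, known or untested is meant among the compounds shown, and "the series" means these compounds.

Measured in a functional assay on THP-1 cells (Homo sapiens) for cytotoxicity, read by MTT assay, with a stated time of 24 h; on this read-out higher numbers stand for weaker inhibition and lower numbers for stronger inhibition:
- compound 1 `COc1cc(/C=C2\CN(C)C/C(=C\c3ccccc3F)C2=O)cc(OC)c1` gives 1170 nM
- compound 2 `COc1cc(/C=C2\CN(C)C/C(=C\c3ccc(Cl)cc3Cl)C2=O)cc(OC)c1` gives 6070 nM
- compound 3 `COc1cc(/C=C2\CN(C)C/C(=C\c3ccc(C#N)cc3)C2=O)cc(OC)c1` gives 940 nM

Compound 2 carries the highest number of the three, and it stands apart from the other two: a 5.2-fold higher number from compound 1 to compound 2 (0.72 log units; beyond the scatter) and a 6.5-fold lower number from compound 2 to compound 3 (0.81 log units; beyond the scatter). Between the other two there is only a 1.2-fold lower number from compound 1 to compound 3 (0.10 log units; within the scatter).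

The next compound, compound 4 `COc1cc(/C=C2\CN(C)C/C(=C\c3ccc(Cl)cc3Cl)C2=O)cc(OC)c1OC`, departs from compound 2 at a single place: methoxy in place of hydrogen on an aromatic carbon. In words, this is methoxy in place of hydrogen on an aromatic carbon. Within the data shown here, none of the measured steps adds or removes a methoxy, since all three exchange the substituted phenyl on the double-bonded chain carbon. They therefore offer only a guide to size, not to direction. With compound 2 at the top of the range at 6070 nM, a modest move toward a lower number in this assay is expected, though the data cannot confirm this. The expected change is a 2.0-fold lower number from compound 2 to compound 4 (0.31 log units; beyond the scatter). The estimated value for compound 4 is 3000 nM, with an expected range from 1000 nM to 9000 nM.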

Compound 4, half-maximal inhibitory concentration: 5020 nM
For compound 4 the middle estimate is 1.7-fold (0.22 log units) below the measured one, and the stated range covers the measured number.
By their numbers in this assay, from the lowest: compounds 3 and 1 (each within the scatter of the next); then compounds 4 and 2 (each within the scatter of the next).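

In this assay, among these compounds, the earlier steps all exchanged the substituted phenyl on the double-bonded chain carbon, whereas this change places methoxy on an aromatic carbon ortho to two methoxy groups and para to a large group, and it yields a 1.2-fold lower number from compound 2 to compound 4 (0.08 log units; within the scatter). With the 2,4-dichlorophenyl held constant, this position therefore accepts methoxy in place of hydrogen without a change beyond the scatter, unlike the exchange that gave a 5.2-fold higher number from compound 1 to compound 2 (0.72 log units; beyond the scatter). Nothing shown gives a reason for this result.

From the compounds shown here alone, it remains open whether the added methoxy would read the same alongside the 2-fluorophenyl of compound 1 or the 4-cyanophenyl of compound 3. Also open, going by these compounds, is how an amine, a carboxylic acid or a longer alkoxy chain would fare at this position.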